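The compounds below may be only part of what the source reports. "The series", "measured", "known", "first", "only" and "open" are said of these compounds alone.

Working notes on the series. In a functional assay on MES-SA cells (Homo sapiens) for cytotoxicity, read by luminescence and CellTiter-Glo, with a stated time of 72 h (on this read-out higher numbers stand for weaker inhibition and lower numbers for stronger inhibition), compound 3 (`COC[C@H](NC(=O)c1cc(C)on1)C(=O)N[C@H](C(=O)N[C@@H](CC(C)C)C(=O)[C@@]1(C)CO1)C(C)C`) gives 57 nM and compound 1 (`CC[C@H](NC(=O)[C@H](COC)NC(=O)c1cc(C)on1)C(=O)N[C@@H](CC(C)C)C(=O)[C@@]1(C)CO1`) gives 92 nM, two values within the scatter of each other. Compound 2 (`COC[C@H](NC(=O)c1cc(C)on1)C(=O)N[C@@H](CC1CCCCC1)C(=O)N[C@@H](CC(C)C)C(=O)[C@@]1(C)CO1`) gives 210 nM, and the step of a 3.7-fold lower number from compound 2 to compound 3 (0.57 log units; beyond the scatter) sets it apart from compound 3.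

Compound 4 (`COC[C@H](NC(=O)c1cc(C)on1)C(=O)N[C@@H](C)C(=O)N[C@@H](CC(C)C)C(=O)[C@@]1(C)CO1`) has methyl in place of isopropyl on a saturated chain carbon bound to an amide-type nitrogen and a carbonyl carbon. All three measured steps touch this same chain. The step of a 1.6-fold lower number from compound 1 to compound 3 (0.21 log units; within the scatter) stays within the scatter, while a 2.3-fold higher number from compound 1 to compound 2 (0.36 log units; beyond the scatter) is modest. Among the compounds with values here, no measured compound has methyl on this carbon, so the expectation is an extrapolation and carries a wide range.

In this assay a small move to a higher number is expected, not clearly beyond the scatter. The expected step is a 1.9-fold higher number from compound 3 to compound 4 (0.29 log units; within the scatter). For compound 4 the estimated value is 110 nM, with an expected range of 45 nM to 270 nM.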

Compound 4, half-maximal inhibitory concentration in the MES-SA assay: 28 nM
Compound 4: the middle estimate sits 3.9-fold (0.59 log units) above what was measured, and the stated range ends above it.
By their numbers in the MES-SA assay, from the lowest: compound 4; then compounds 3 and 1 (each within the scatter of the next); then compound 2.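

In the MES-SA assay compound 4 with methyl on this carbon gives 28 nM as the lowest number of the four, and every step to it lies beyond the scatter: a 2.0-fold lower number from compound 3 to compound 4 (0.31 log units; beyond the scatter) and a 3.3-fold lower number from compound 1 to compound 4 (0.52 log units; beyond the scatter) and a 7.5-fold lower number from compound 2 to compound 4 (0.88 log units; beyond the scatter). The earlier compounds shown here set only the cyclohexylmethyl of compound 2 apart; this result shows that the number still responds when isopropyl gives way to methyl, although compound 1 and compound 3 stay within the scatter of each other and so show no steady order along the series. In a physicochemical assay for metabolic stability, in simulated intestinal fluid, with a stated time of 15 min, tested at 4 uM (on this read-out lower numbers stand for a less stable compound and higher numbers for a more stable compound), compound 3 gives 95% and compound 4 gives 100% and the same change stays within the scatter (a number 5 percentage points higher from compound 3 to compound 4 (within the scatter)).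

Nothing measured here accounts for the result. As far as these compounds go, whether an amine or a carboxylic acid on this carbon would hold the number of compound 4 stays open.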